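A few compounds are considered here, and "the series" means these few. Any claim that something is new, unique, unknown or untested is made for them only; others in the source may bear on it.

Measured in an ADME assay on MT4 cells (Homo sapiens) for cytotoxicity, read by MTT assay, with a stated time of 5 days; a lower number here means that less compound is tolerated, a higher number that more compound is tolerated:
- compound 1 `CCCCNc1cc(Oc2c(OC)cc3cc(C#N)ccc3c2OC)nc(Nc2ccc(C#N)cc2)n1`: > 125000 nM
- compound 2 `COc1cc2cc(C#N)ccc2c(OC)c1Oc1cc(NC(C)(C)C)nc(Nc2ccc(C#N)cc2)n1`: > 125000 nM

Compound 1 stands only at a limit of this assay, > 125000 nM, and not at a number. Compound 2 likewise gives only a limit, > 125000 nM. Both measured compounds therefore share (the limit of > 125000 nM in this assay, at which 2 of the 2 values shown sit).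

Compound 3 `CCCC(C)Nc1cc(Oc2c(OC)cc3cc(C#N)ccc3c2OC)nc(Nc2ccc(C#N)cc2)n1` departs from compound 1 by one change: methyl in place of hydrogen on a saturated chain carbon bound to a nitrogen on an aromatic ring and a saturated chain carbon. The closest measured evidence is a step that the two limits leave unreadable from compound 1 to compound 2, where tert-butyl stands in place of butyl on a nitrogen on an aromatic ring. Its size cannot be read, so it gives no measured shift to carry over, and neither compound has left the limit. No step beyond the scatter is therefore expected, and the estimated step is a number no higher from compound 1 to compound 3 (the limit leaves the size open). Compound 3 is most likely to be reported at the same limit. For compound 3 the estimate is 125000 nM. The expected range for this compound runs from 50000 nM to 200000 nM.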

Compound 3, half-maximal cytotoxic concentration: > 125000 nM
Compound 3 ended at the assay's limit (the forecaster's own chance of this, stated with the estimate: 80%); the middle value sits exactly at the limit.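

No step can be read between compound 1, compound 2 and compound 3 in this assay, since all three stand at a limit and not at a number: the limit of > 125000 nM in this assay, at which 3 of the 3 values shown sit. The compounds shown leave open whether butyl, tert-butyl and 1-methylbutyl differ at all in this assay, and at what concentration any of them would become cytotoxic.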